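The source may report more compounds than this note shows. Statements on the series, on what has been measured and on what is new or still open speak of the compounds shown alone.

Compound 1 `Cc1cc(=O)oc2cc(OCc3cn(-c4ccc(F)c(Cl)c4)nn3)ccc12`: in an ADME assay on Huh-7 cells (Homo sapiens) for cytotoxicity, read by MTT assay, with a stated time of 72 h (on this read-out lower numbers stand for higher toxicity in this test and higher numbers for lower toxicity in this test), compound 1 gives > 100 ug/mL, which is a limit of the assay and not a number.
Compound 2 `Cc1cc(C)cc(-n2cc(COc3ccc4c(C)cc(=O)oc4c3)nn2)c1`: in this assay compound 2 gives > 100 ug/mL, again a limit of the assay rather than a number.

Within the data shown here, compound 2 thus stands only at a limit in this assay, and the one further value shown is a limit as well, as the limit of > 100 ug/mL in this assay, at which 2 of the 2 values shown sit, records. Among the measured compounds shown here, the single measured step, a step that the two limits leave unreadable from compound 1 to compound 2, cannot be read in size or direction, since both of its ends are limits. Compound 3 `Cc1cc(=O)oc2cc(OCc3cn(CCO)nn3)ccc12` differs from compound 2 in one place: 2-hydroxyethyl in place of 3,5-dimethylphenyl on an aromatic nitrogen. For the measured compounds named here, no measured step bears readably on this change, so neither a size nor a direction can be drawn from the step that the two limits leave unreadable from compound 1 to compound 2; it shows only that both of its compounds sit at the limit. Compound 3 is therefore expected to sit at that limit too, with the step of a number no higher from compound 2 to compound 3 (the limit leaves the size open) expected to be nothing readable. Compound 3 is estimated in this assay at 100 ug/mL, in a range from 50 ug/mL to 200 ug/mL, and most probably it will again be reported only as a limit.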

Compound 3, half-maximal cytotoxic concentration: > 100 ug/mL
Compound 3 ended at the assay's limit (the forecaster's own chance of this, stated with the estimate: 80%); the middle value lies on the limit itself.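

Among these compounds, compound 3 also gives a limit of the assay and not a number, so no step among compound 1, compound 2 and compound 3 can be read in this assay: the limit of > 100 ug/mL in this assay, at which 3 of the 3 values shown sit. The compounds shown leave open at what concentration any of the three becomes toxic in this assay, and whether 2-hydroxyethyl, 3,5-dimethylphenyl and 3-chloro-4-fluorophenyl differ there at all.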